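A few compounds are considered here, and "the series" means these few. Any claim that something is new, unique, unknown or untested is made for them only; others in the source may bear on it.

In an ADME assay on MT4 cells (Homo sapiens) for cytotoxicity, read by MTT assay, with a stated time of 5 days (on this read-out lower numbers stand for higher toxicity in this test and higher numbers for lower toxicity in this test), compound 1 `CNc1cc(Oc2c(OC)cc3cc(C#N)ccc3c2OC)nc(Nc2ccc(C#N)cc2)n1` gives 239000 nM as a measured number. Compound 2 `COc1cc2cc(C#N)ccc2c(OC)c1Oc1cc(NC(C)C)nc(Nc2ccc(C#N)cc2)n1` is reported as > 125000 nM and that is a limit of the assay, not a number. For compound 2 this leaves the limit of > 125000 nM in this assay, at which 1 of the 2 values shown sits, and nothing more exact.

The next structure, compound 3 `CCC(CC)Nc1cc(Oc2c(OC)cc3cc(C#N)ccc3c2OC)nc(Nc2ccc(C#N)cc2)n1`, alters one group of compound 2: pentan-3-yl in place of isopropyl on a nitrogen on an aromatic ring in short, pentan-3-yl in place of isopropyl on a nitrogen on an aromatic ring.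

For the measured compounds named here, only one measured step bears on this change, a swap at that same nitrogen with isopropyl in place of methyl. That step, a step that the limit leaves unreadable from compound 1 to compound 2 gives no size that could be carried over to the new swap. Going by the values given here, the one true number in hand is that of compound 1 at 239000 nM and it serves as the best guide to where compound 3 may fall. No step beyond the usual scatter is therefore expected in either direction, and the assay may again return only a limit.

Expected in this assay is a step that the limit leaves unreadable from compound 2 to compound 3 as the estimated step for now. For compound 3 the estimated value is 150000 nM with an expected range from 50000 nM to 280000 nM overall.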

Compound 3, half-maximal cytotoxic concentration: > 125000 nM
Compound 3: a limit, no number (the forecaster's own chance of this, stated with the estimate: 55%); the middle value is on the limit's open side.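

Compound 3 gives > 125000 nM as a limit of the assay and not a number. No step among compound 1, compound 2 and compound 3 can be read, because the comparisons rest on a limit: the limit of > 125000 nM in this assay, at which 2 of the 3 values shown sit.

Still open, going by these compounds, is where compound 2 and compound 3 truly fall in this assay and whether pentan-3-yl in place of isopropyl changes the result at all.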